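Swapping the cyclic amine for a dimethylamino group

The source may report more compounds than this note shows. Statements on the series, on what has been measured and on what is new or still open speak of the compounds shown alone.

Measured so far:
- compound 1 `COc1cc(OC)c2c(=O)cc(-c3ccc(OCCBr)cc3)oc2c1`: in a functional assay (Homo sapiens) for antiproliferative activity, read by resazurin assay, with a stated time of 48 h, tested at 5 uM (on this read-out lower numbers stand for a weaker effect and higher numbers for a stronger effect at the one concentration tested), compound 1 is recorded as "not active" (no number reported)
- compound 2 `COc1cc(OC)c2c(=O)cc(-c3ccc(OCC(O)CN4CCCC4)cc3)oc2c1`: in this assay compound 2 gives 21%

Among the measured compounds shown here, compound 2 carries the only number reported in this assay; compound 1 has no number at all, only the note that it is inactive, so compound 2 stands alone as the reference point and no step between measured compounds can be drawn.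

Compound 3 `COc1cc(OC)c2c(=O)cc(-c3ccc(OCC(O)CN(C)C)cc3)oc2c1` is not yet measured. It differs from compound 2 in one place: dimethylamino in place of pyrrolidin-1-yl on a saturated chain carbon, two bonds along the chain from an oxygen on a saturated carbon. The pyrrolidin-1-yl group and the dimethylamino group are both small, each with one hydrogen-bond acceptor and no charge, and nothing in the two measured compounds indicates how such a swap shifts the read-out in this assay. The expected step of a number 3 percentage points lower from compound 2 to compound 3 (within the scatter) is therefore none beyond the scatter. Compound 3 is estimated at 18%, with a range from 5% to 34%.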

Compound 3, a percentage reported as inhibition, at one concentration (the size of the read-out at that concentration, not a potency): 42%
Compound 3: the middle estimate sits 24 percentage points below what was measured, outside the stated range (above it).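

In this assay, dimethylamino in place of pyrrolidin-1-yl gives a number 21 percentage points higher from compound 2 to compound 3 (beyond the scatter), so the read-out responds to a change at this place on the chain. The swap removes the ring and leaves fewer heavy atoms, while the counts of hydrogen-bond donors and acceptors stay the same, so those two counts alone do not separate the two groups here. No independent measurement shows why the number moves.

Going by these compounds, it remains open whether the ring itself or simply the size of the group matters: a diethylamino group would keep the open form with more carbon, and a morpholin-4-yl group would keep a ring with an added oxygen. With one concentration, the step also says nothing about potency.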